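Propyl Chain Terminus Swapped from Piperazine to Aniline

The source may report more compounds than this note shows. Statements on the series, on what has been measured and on what is new or still open speak of the compounds shown alone.

Measured compounds:
Compound 1, `CCCn1c(N)c(-c2nc3ccccc3[nH]2)c2nc(C#N)c(C#N)nc21`, gives > 50000 nM in a functional assay on HeLa cells (Homo sapiens) for antiproliferative activity, read by MTT assay, with a stated time of 48 h (on this read-out lower numbers stand for stronger inhibition and higher numbers for weaker inhibition), which is a limit of the assay and not a number.
Compound 2, `CCN(CC)CCCn1c(N)c(-c2nc3ccccc3[nH]2)c2nc(C#N)c(C#N)nc21`, gives 3150 nM in this assay.
Compound 3, `CN1CCN(CCCn2c(N)c(-c3nc4ccccc4[nH]3)c3nc(C#N)c(C#N)nc32)CC1`, gives 15600 nM in this assay.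

Compound 3 holds the highest of the two numbers shown, and its nearest neighbour is compound 2, separated by a 5.0-fold higher number from compound 2 to compound 3 (0.69 log units; beyond the scatter). Compound 4, `N#Cc1nc2c(-c3nc4ccccc4[nH]3)c(N)n(CCCNc3ccccc3)c2nc1C#N`, differs from compound 3 in one place: anilino in place of 4-methylpiperazin-1-yl on a saturated chain carbon, three bonds along the chain from an aromatic nitrogen. Three measured steps change the group at this same chain carbon: an at least 15-fold lower number from compound 1 to compound 2 (1.20 log units; beyond the scatter), an at least 3.2-fold lower number from compound 1 to compound 3 (0.50 log units; beyond the scatter) and a 5.0-fold higher number from compound 2 to compound 3 (0.69 log units; beyond the scatter). They show that the terminal group moves the number in this assay by modest to large amounts, and that the unsubstituted chain of compound 1 reaches only a limit, (the limit of > 50000 nM in this assay, at which 1 of the 3 values shown sits). Among the measured compounds shown here, no measured step replaces a saturated ring amine with an anilino group, so the direction of the new step rests on analogy alone. The account expects compound 4 to move back toward the limit seen for compound 1, by a 1.6-fold higher number from compound 3 to compound 4 (0.20 log units; within the scatter). Compound 4 is estimated at 25000 nM, with a range from 6000 nM to 60000 nM.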

Compound 4, half-maximal inhibitory concentration: 26300 nM
Compound 4: middle estimate off by 1.1-fold (0.02 log units), on the low side, within the range that was stated.
By their numbers in this assay, from the lowest: compound 2; then compounds 3 and 4 (each within the scatter of the next). At a limit, above all of these: compound 1.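

In this assay, anilino in place of 4-methylpiperazin-1-yl gives a 1.7-fold higher number from compound 3 to compound 4 (0.23 log units; within the scatter), so a terminal ring with no saturated amine is not separated from the piperazine at this chain carbon. The diethylamino group stands apart from both, with an 8.3-fold higher number from compound 2 to compound 4 (0.92 log units; beyond the scatter) adding to the earlier gap to the piperazine, and among the three substituted chains shown it alone is separated from the other two. Compound 1 holds a limit of the assay and not a number, and the anilino step from it reads only as an at least 1.9-fold lower number from compound 1 to compound 4 (0.27 log units; that floor lies within the scatter), so no clear gain over the unsubstituted propyl chain can be claimed: the limit of > 50000 nM in this assay, at which 1 of the 4 values shown sits.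

Open, from the compounds shown here alone, is how a dimethylamino or pyrrolidine group at this chain carbon would compare with diethylamino. Also open, going by these compounds, is whether a butyl chain carrying diethylamino would stay close to compound 2 at 3150 nM.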